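This account rests on a few compounds, and the source may have more. Where it says the series, first, only, none or still open, it means among the compounds named here.

Working notes on the series. Within the data shown here, in a physicochemical assay for solubility, in phosphate buffer, measured as kinetic solubility (a lower number here means a less soluble compound, a higher number a more soluble compound), compound 1 (`CC(C)C(/C=C1\NC(=O)NC1=O)c1ccc(-c2ccc3cccc(F)c3c2)[nH]c1=O`) gives 10700 nM and compound 2 (`CC(C)C(/C=C1\SC(=O)NC1=O)c1ccc(-c2ccc3cccc(F)c3c2)[nH]c1=O`) gives 25600 nM, the higher of the two numbers so far. Compound 3 (`CC(C)C(/C=C1/C(=O)NC(=O)N1C)c1ccc(-c2ccc3cccc(F)c3c2)[nH]c1=O`) is still unmeasured and differs from compound 2 at one place: a group of 9 heavy atoms (5 carbon, 2 nitrogen, 2 oxygen; one five-membered non-aromatic ring with 2 hetero atoms) in place of a group of 8 heavy atoms (4 carbon, 1 nitrogen, 2 oxygen, 1 sulfur; one five-membered non-aromatic ring with 2 hetero atoms), on a saturated chain carbon bound to an aromatic carbon and a saturated chain carbon. The entering group has no sulfur, as is also true of the group in compound 1.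

Among the measured compounds shown here, only one measured step bears on this change: a 2.4-fold higher number from compound 1 to compound 2 (0.38 log units; beyond the scatter). That step is modest, and a single pair gives thin support. Compound 3 also carries a group absent from both measured compounds, so part of that step is expected to be given back, but not all of it. In this assay, the expected step is a 1.6-fold lower number from compound 2 to compound 3 (0.20 log units; within the scatter), with no move beyond the scatter anticipated. For compound 3 the estimated value is 16000 nM, with an expected range of 6500 nM to 40000 nM.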

Compound 3, solubility: 34800 nM
Compound 3: the middle estimate sits 2.2-fold (0.34 log units) below what was measured; low and high end bracket the measured number.
By their numbers in this assay, from the lowest: compound 1; then compounds 2 and 3 (each within the scatter of the next).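

In this assay, methyl in place of hydrogen on an amide-type nitrogen in a ring gives a 3.3-fold higher number from compound 1 to compound 3 (0.51 log units; beyond the scatter) and is a change of one small group that reads beyond the scatter. Exchanging the sulfur-containing ring for the methylated ring gives a 1.4-fold higher number from compound 2 to compound 3 (0.13 log units; within the scatter) and stays within the scatter, so this read-out does not separate the two groups, and sulfur in the ring is not needed to stay level with compound 2. No measurement is at hand that explains either step.

As far as these compounds go, whether an ethyl group or a longer chain on that ring nitrogen keeps the number level with compound 3 stays open. So does the outcome with an amine or a carboxylic acid carried on that nitrogen.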